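Carbonyl substituents on the shared core, towards compound 4

This account rests on a few compounds, and the source may have more. Where it says the series, first, only, none or still open, it means among the compounds named here.

Measured in a functional assay with Oryctolagus cuniculus as the target (on this read-out higher numbers stand for weaker inhibition and lower numbers for stronger inhibition), all three values being limits:
compound 1 `COc1ccc(-c2nc(C(N)=O)sc2-c2ccc(OC)cc2)cc1` gives the limit > 1000 nM
compound 2 `CCN(CC)C(=O)c1nc(-c2ccc(OC)cc2)c(-c2ccc(OC)cc2)s1` gives the limit < 10 nM
compound 3 `COc1ccc(-c2nc(C(=O)N3CCOCC3)sc2-c2ccc(OC)cc2)cc1` gives the limit < 10 nM

Compound 3 stands at the limit < 10 nM, so no number is known for it. Compound 4 `COc1ccc(-c2nc(C(=O)N3CCCCC3CCO)sc2-c2ccc(OC)cc2)cc1` differs from it as follows: 2-(2-hydroxyethyl)piperidin-1-yl in place of morpholin-4-yl on a carbonyl carbon. For the measured compounds named here, two measured steps bear on this change, both large: an at least 100-fold lower number from compound 1 to compound 2 (2.00 log units; beyond the scatter) and an at least 100-fold lower number from compound 1 to compound 3 (2.00 log units; beyond the scatter). The remaining step, a step that the two limits leave unreadable from compound 2 to compound 3, gives no size. Compound 4 keeps a substituted nitrogen on the carbonyl carbon, as compound 2 and compound 3 do, so no step beyond the scatter is expected in this assay. The expected step is a step that the limit leaves unreadable from compound 3 to compound 4. For compound 4 the estimate is 6 nM, with an expected range of 1 nM to 50 nM.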

Compound 4, half-maximal inhibitory concentration: 45 nM
The estimate for compound 4 lay 7.5-fold (0.88 log units) below the measured number; the measured number falls inside the stated range.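

In this assay, a substituted nitrogen on the carbonyl carbon does not by itself settle the read-out: 2-(2-hydroxyethyl)piperidin-1-yl gives an at least 4.5-fold higher number from compound 3 to compound 4 (0.65 log units; beyond the scatter) and an at least 4.5-fold higher number from compound 2 to compound 4 (0.65 log units; beyond the scatter), while still giving an at least 22-fold lower number from compound 1 to compound 4 (1.34 log units; beyond the scatter). Substituted amides at this position therefore differ from one another by more than the scatter. Compound 4 carries the only exact number in the set, so these steps are minimum sizes: the limit of < 10 nM in this assay, at which 2 of the 4 values shown sit.

From the compounds shown here alone, whether the step belongs to the 2-hydroxyethyl chain or to the piperidine ring stays open; a plain piperidin-1-yl would separate the two. The step between compound 2 and compound 3 cannot be read.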